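This account rests on a few compounds, and the source may have more. Where it says the series, first, only, none or still open, it means among the compounds named here.

Measured compounds:
Compound 1, `CCCCc1cc2ccccc2nc1-c1cc(-c2ccccc2)no1`. In a functional assay on COLO 205 cells (Homo sapiens) for inhibition, read by MTT assay, with a stated time of 24 h (on this read-out higher numbers stand for weaker inhibition and lower numbers for stronger inhibition), compound 1 gives > 100000 nM, which is a limit of the assay rather than a number.
Compound 2, `CCCCCc1cc2ccccc2nc1-c1cc(-c2ccccc2)no1`. In this assay compound 2 gives > 100000 nM, again a limit of the assay.

Compound 1 therefore stands only at a limit in this assay, and the evidence is confined to the limit of > 100000 nM in this assay, at which 2 of the 2 values shown sit. Within the data shown here, the one measured step, a step that the two limits leave unreadable from compound 1 to compound 2, is unreadable because both of its ends are limits, so no size can be drawn from it. Compound 3, `CCCCc1cc2ccccc2nc1-c1cc(-c2ccc(C(F)(F)F)cc2)no1`, is not yet measured. It differs from compound 1 by trifluoromethyl in place of hydrogen on an aromatic carbon. Among the measured compounds shown here, no measured step bears on this change: the only step in hand concerns a methyl on the saturated chain and is itself unreadable. In the absence of any readable step, the expected step for compound 3 is a number no higher from compound 1 to compound 3 (the limit leaves the size open), with no direction that the data support beyond the scatter. Compound 3 is accordingly expected to give about 100000 nM, estimated to fall between 20000 nM and 300000 nM, most likely again as a limit.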

Compound 3, half-maximal inhibitory concentration: 11900 nM
Estimate against measurement, compound 3: 8.4-fold (0.92 log units) above; the measured number lies below the stated range.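

In this assay, the aromatic carbon para to a large group is the first place shown where a change brings a compound off the limit: trifluoromethyl in place of hydrogen there gives an at least 8.4-fold lower number from compound 1 to compound 3 (0.92 log units; beyond the scatter). The starting end of this step is a limit, so the step sets a floor on its size and leaves the full size unknown, though it is printed as beyond the scatter. The step on the saturated chain cannot be read, and compound 3 now stands alone outside the limit shared by the other compounds: the limit of > 100000 nM in this assay, at which 2 of the 3 values shown sit.

The compounds shown leave open whether this gain belongs to trifluoromethyl itself or would also come with another group on the same carbon, such as chlorine, a methoxy group, a nitrile, an amine or a carboxylic acid. They also leave open whether trifluoromethyl at this place would bring a readable number on the core of compound 2, with its longer chain, and how far a second group on the same ring would carry the number.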